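A few compounds are considered here, and "the series" means these few. Any claim that something is new, unique, unknown or untested is made for them only; others in the source may bear on it.

Measured so far in an ADME assay on PBMC cells (Homo sapiens) for cytotoxicity; on this read-out lower numbers stand for higher toxicity in this test and higher numbers for lower toxicity in this test:
- compound 1 `CC(CCNC(=O)c1c(Cl)cncc1Cl)N1CCC(C(Oc2cccc(Cl)n2)c2ccc(OC(F)(F)F)cc2)CC1` gives 6000 nM
- compound 2 `CC(CCNC(=O)c1c(Cl)cncc1Cl)N1CCC(C(Oc2ccccn2)c2ccc(Br)cc2)CC1` gives 33700 nM
- compound 3 `Cc1cccnc1OC(c1ccc(C(F)(F)F)cc1)C1CCN(C(C)CCNC(=O)c2c(Cl)cncc2Cl)CC1` gives 33000 nM

Compound 1 has the lowest number of the three, which makes it the most toxic in this test. Its gaps to compound 2 and to compound 3 both lie beyond the usual scatter, while those two lie within the scatter of each other.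

Next in line is compound 4 `CC(CCNC(=O)c1c(Cl)cncc1Cl)N1CCC(C(Oc2cccc(Cl)n2)c2ccc(S(C)(=O)=O)cc2)CC1`, which differs from compound 1 in one place: methylsulfonyl in place of trifluoromethoxy on an aromatic carbon. This puts methylsulfonyl in place of trifluoromethoxy on an aromatic carbon, para to a large group.

Among the measured compounds shown here, no measured pair isolates this change, so the direction rests on thin evidence. For the measured compounds named here, compound 2 at 33700 nM and compound 3 at 33000 nM show only that numbers well above that of compound 1 occur in this small set. Trifluoromethoxy appears only in compound 1 among the three measured compounds. A moderate upward step in this assay is therefore expected, probably beyond the scatter, though with low confidence. The expected step is a 3.0-fold higher number from compound 1 to compound 4 (0.48 log units; beyond the scatter). For compound 4 the estimated value is 18000 nM, with an expected range from 7000 nM to 45000 nM.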

Compound 4, half-maximal cytotoxic concentration: > 29500 nM
Compound 4: only a limit was reported (the forecaster's own chance of this, stated with the estimate: 8%); middle value at least 1.6-fold (0.21 log units) from the limit.
By their numbers in this assay, from the lowest: compound 1; then compounds 3 and 2 (each within the scatter of the next).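

In this assay compound 4 gives > 29500 nM, which is a limit of the assay and not a number. Methylsulfonyl in place of trifluoromethoxy on an aromatic carbon, para to a large group, gives an at least 4.9-fold higher number from compound 1 to compound 4 (0.69 log units; beyond the scatter), so the change moves the read-out towards lower toxicity in this test by more than the usual scatter. This is the only pair shown that differs in one place, which makes it the first direct reading at this position and shows that the group there can set the number in this assay while the rest of the core of compound 1 stays the same.

How far the step reaches remains open, since its upper end is not defined: the limit of > 29500 nM in this assay, at which 1 of the 4 values shown sits.

Also open, as far as these compounds go, is whether the step follows from methylsulfonyl itself or from the loss of trifluoromethoxy, and whether a nitrile, an amine or a carboxylic acid at the same position would read like compound 1 or like compound 4.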